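Halogen swap on the benzyl group of compound 1

The source may report more compounds than this note shows. Statements on the series, on what has been measured and on what is new or still open speak of the compounds shown alone.

Three compounds have a result in a functional assay on HGC-27 cells (Homo sapiens) for inhibition, read by MTT assay, with a stated time of 72 h; a higher number here means a weaker inhibitor, a lower number a stronger inhibitor. Within the data shown here, compound 1 `Cc1cc(N2CC[C@@H](C)[C@@H](N(C)c3ncnc4[nH]ccc34)C2)n2nc(SCc3ccccc3Br)nc2n1` gives 21300 nM, the only actual number in the set. Compound 2 `CCCCCc1c(C)nc2nc(SCc3ccc(Cl)cc3)nn2c1N1CC[C@@H](C)[C@@H](N(C)c2ncnc3[nH]ccc23)C1` reaches only a limit, > 100000 nM. Compound 3 `CCc1cc(N2CC[C@@H](C)[C@@H](N(C)c3ncnc4[nH]ccc34)C2)n2ncnc2n1` also reaches only a limit, > 100000 nM. Coverage is thin, with the limit of > 100000 nM in this assay, at which 2 of the 3 values shown sit, and no measured pair differs in one place.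

Compound 4 `Cc1cc(N2CC[C@@H](C)[C@@H](N(C)c3ncnc4[nH]ccc34)C2)n2nc(SCc3cc(Cl)ccc3Cl)nc2n1` departs from compound 1 at a single point: 2,5-dichlorophenyl in place of 2-bromophenyl on a saturated chain carbon bound to a sulfur. It carries 2,5-dichlorophenyl in place of 2-bromophenyl on a saturated chain carbon bound to a sulfur, and the rest of the structure is unchanged.

Among the measured compounds shown here, with no measured step to gauge this swap, no shift beyond the usual scatter is expected in this assay, and no direction is favoured. The expectation rests on compound 1 at 21300 nM alone. The estimated step is a 1.1-fold lower number from compound 1 to compound 4 (0.03 log units; within the scatter). For compound 4 the estimated value is 20000 nM, with an expected range from 7000 nM to 60000 nM.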

Compound 4, half-maximal inhibitory concentration: 19200 nM
For compound 4 the middle estimate is 1.0-fold (0.02 log units) above the measured one; the range from low to high includes it.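

Among these compounds, the (2-bromobenzyl)sulfanyl to (2,5-dichlorobenzyl)sulfanyl swap gives the first readable step: in this assay the change produces a 1.1-fold lower number from compound 1 to compound 4 (0.05 log units; within the scatter). On a saturated chain carbon bound to a sulfur, 2-bromophenyl and 2,5-dichlorophenyl therefore cannot be told apart in this read-out. Among the compounds shown here, the step bundles the loss of bromine with the entry of two chlorines, so it shows only that this combined exchange leaves the value unchanged, not what each halogen does alone.

Still open, on these data alone, is whether the ring tolerates a group of a different kind, such as an amine or a carboxylic acid, in place of halogen. Any much weaker analogue would be hard to size, since the read-out ends in a limit rather than a number: the limit of > 100000 nM in this assay, at which 2 of the 4 values shown sit.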